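A few compounds are considered here, and "the series" means these few. Any claim that something is new, unique, unknown or untested is made for them only; others in the source may bear on it.

Working notes on the series. All three measured compounds share one core and differ only in the group at one end of it. In an assay on isolated protein with Bile acid receptor (Homo sapiens) as the target (a lower number here means that less compound is needed, a higher number that more compound is needed for the effect), compound 1 `COC(=O)/C=C/c1cccc(N(Cc2ccc(/C=C/c3scnc3C)cc2)C(=O)C(C)C)c1` gives 228 nM, compound 2 `COC(=O)/C=C/c1cccc(N(Cc2ccc(-c3cccc(Cl)c3)cc2)C(=O)C(C)C)c1` gives 77 nM, and compound 3 `COC(=O)/C=C/c1cccc(N(Cc2ccc(-c3cccc(OC(F)(F)F)c3)cc2)C(=O)C(C)C)c1` gives 247 nM. Compound 3 thus carries the highest of the three numbers; its nearest neighbour is compound 1, a 1.1-fold higher number from compound 1 to compound 3 (0.03 log units; within the scatter), and its furthest is compound 2, a 3.2-fold higher number from compound 2 to compound 3 (0.51 log units; beyond the scatter). The remaining step, a 3.0-fold lower number from compound 1 to compound 2 (0.47 log units; beyond the scatter), is of similar modest size.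

Compound 4 `COC(=O)/C=C/c1cccc(N(Cc2ccc(-c3ccc(N(C)C)cc3)cc2)C(=O)C(C)C)c1` has not yet been measured. It differs from compound 3 in one place: 4-(dimethylamino)phenyl in place of 3-(trifluoromethoxy)phenyl on an aromatic carbon. Going by the values given here, no measured step exchanges a substituted phenyl for a dimethylamino-bearing one, so the bearing of the earlier steps is indirect. The closest comparison is a 3.2-fold higher number from compound 2 to compound 3 (0.51 log units; beyond the scatter), where one group on the phenyl was swapped for another with a modest shift, while a 1.1-fold higher number from compound 1 to compound 3 (0.03 log units; within the scatter) stayed within the scatter. Changes of this kind in the set have moved the number by modest amounts at most. For compound 4 a modest change in this assay is therefore expected, with direction uncertain, a 1.6-fold lower number from compound 3 to compound 4 (0.22 log units; within the scatter). The estimate for compound 4 is 150 nM, with a range of 50 nM to 450 nM.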

Compound 4, half-maximal effective concentration: 57 nM
Compound 4: the middle estimate sits 2.6-fold (0.42 log units) above what was measured; measured number inside the range.
By their numbers in this assay, from the lowest: compounds 4 and 2 (each within the scatter of the next); then compounds 1 and 3 (each within the scatter of the next).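

In this assay, the change at this aromatic carbon shows that exchanging one substituted phenyl for another can move the number beyond the scatter even when the substituent and its ring position change together: a 4.3-fold lower number from compound 3 to compound 4 (0.64 log units; beyond the scatter), and the step from the ethenyl-linked thiazole is of similar modest size, a 4.0-fold lower number from compound 1 to compound 4 (0.60 log units; beyond the scatter). Going by these compounds alone, the 4-(dimethylamino)phenyl group and the 3-chlorophenyl group are not separated, a 1.4-fold lower number from compound 2 to compound 4 (0.13 log units; within the scatter), so two phenyl groups with different substituents at different ring positions now share the low end of the series, whereas the earlier compounds offered only compound 2 there. No measurement bearing on why these groups differ is available, so the shift remains an observation about the numbers alone.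

The compounds shown leave open whether the substituent or its ring position drives the step, since 3-(dimethylamino)phenyl and 4-chlorophenyl, which would separate the two, are not among them. Going by these compounds, whether a phenyl bearing a carboxylic acid or a primary amine at this place would stay with compound 4 or with compound 3 also remains open.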